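A few compounds are considered here, and "the series" means these few. Any claim that something is new, unique, unknown or untested is made for them only; others in the source may bear on it.

Compound 1 `Cn1c(Cc2nn(C)c(=O)c3ccccc23)nnc1SCCCCCC(=O)Nc1ccc(Cl)cc1Cl` carries, at the end of its chain, an amide to a 2,4-dichlorophenyl group. In an assay on isolated protein (Mus musculus) for inhibition of IL15-IL15 receptor (Homo sapiens), read by resazurin assay, with stated times of 30 min and 2.5 days (on this read-out higher numbers stand for weaker inhibition and lower numbers for stronger inhibition), compound 1 gives 4100 nM. Compound 2 `Cn1c(Cc2nn(C)c(=O)c3ccccc23)nnc1SCCCCCCCC(=O)Nc1ccc(O)cc1` ends instead in an amide to a 4-hydroxyphenyl group, on a chain two carbons longer. For compound 2 this assay reports only a limit, > 30000 nM, not a number. Compound 3 `CC(C)COc1ccc(NC(=O)CSc2nnc(Cc3nn(C)c(=O)c4ccccc34)n2C)cc1`, with a shorter chain and a different amide, gives 30000 nM in this assay. For the measured compounds named here, the one measured step touching the amide group is an at least 7.3-fold higher number from compound 1 to compound 2 (0.86 log units; beyond the scatter): swapping the dichlorinated ring for the hydroxylated one pushed the number up to the edge of what the assay reports, the point where one of three values sits (the limit of > 30000 nM in this assay, at which 1 of the 3 values shown sits). Compound 4 `Cn1c(Cc2nn(C)c(=O)c3ccccc23)nnc1SCCCCCCCC(=O)Nc1ccc(Br)cc1Br` differs from compound 2 in one place: 2,4-dibromophenyl in place of 4-hydroxyphenyl on an amide-type nitrogen. This runs the measured step backwards, restoring a dihalogenated ring of the same substitution pattern on the same chain length. A clearly lower number is therefore expected. Compound 4 is expected to give 5000 nM in this assay, within a range from 1500 nM to 30000 nM. The expected step is an at least 6.0-fold lower number from compound 2 to compound 4 (0.77 log units; beyond the scatter), though a result at the limit cannot be ruled out.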

Compound 4, half-maximal inhibitory concentration: 1500 nM
For compound 4 the middle estimate is 3.3-fold (0.52 log units) above the measured one; measured number inside the range.
By their numbers in this assay, from the lowest: compound 4; then compound 1; then compound 3.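

Keeping the chain the same, 2,4-dibromophenyl in place of 4-hydroxyphenyl on the amide-type nitrogen gives an at least 20-fold lower number from compound 2 to compound 4 (1.30 log units; beyond the scatter) in this assay. The earlier step changed the ring and the chain length together, whereas here only the ring changes and the number still moves, which shows that the group on this nitrogen matters on its own. The true size of the step stays unknown, as compound 2 gives only a limit of the assay: the limit of > 30000 nM in this assay, at which 1 of the 4 values shown sits.

The compounds shown leave open which part of the change counts, losing the hydroxyl or gaining either bromine, and an unsubstituted phenyl or a 4-bromophenyl on the same nitrogen and chain would help to separate these. Also open, on these data alone, is how a 2,4-dibromophenyl amide behaves on a shorter chain.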